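The compounds below may be only part of what the source reports. "The series", "measured", "known", "first", "only" and "open" are said of these compounds alone.

Measured compounds:
compound 1, `Cn1c(-c2ccc(C#N)cc2)cnc1NC(=O)c1ccc(F)cc1`: > 50000 nM
compound 2, `Cn1c(-c2ccc(C#N)cc2)cnc1NC(=O)c1ncc[nH]1`: > 100000 nM

In a toxicity assay on THP-1 cells (Homo sapiens) for inhibition (a lower number here means that less compound is tolerated, a higher number that more compound is tolerated), compound 1 gives > 50000 nM, which is a limit of the assay and not a number. Compound 2 likewise gives only a limit, > 100000 nM. The step that the two limits leave unreadable from compound 1 to compound 2 therefore cannot be read. Compound 3, `Cn1c(-c2cccc(F)c2)cnc1NC(=O)c1ccc(F)cc1`, is not yet measured; it differs from compound 1 by 3-fluorophenyl in place of 4-cyanophenyl on an aromatic carbon. Among the compounds with values here, no measured step touches this part of the structure, so no direction beyond the scatter is expected, and the only guide is that compound 1 sits at the limit of > 50000 nM in this assay, at which 1 of the 2 values shown sits. Compound 3 is expected to give 50000 nM, from 20000 nM to 120000 nM. That would be an expected step of a number no higher from compound 1 to compound 3 (the limit leaves the size open).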

Compound 3, half-maximal cytotoxic concentration: 58000 nM
Beside the measured number, compound 3's estimate is 1.2-fold (0.06 log units) below it, and the stated range covers the measured number.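

The step from compound 1 to compound 3 cannot be read, as compound 1 has only a limit of the assay. The compounds shown leave open whether 3-fluorophenyl in place of 4-cyanophenyl changes tolerance in this assay at all.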